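The source may report more compounds than this note shows. Statements on the series, on what has been measured and on what is new or still open speak of the compounds shown alone.

Of the compounds shown here, three sharing one core have been measured in a physicochemical assay for acid dissociation. Compound 1 `COc1ccc(F)cc1CNCCCNc1ccnc2cc(Cc3cc(C)cc(C)c3)ccc12` gives 9.47. Compound 2 `COc1ccc(F)cc1CNCCCNc1ccnc2cc(C3CCCCC3)ccc12` gives 9.47, and compound 3 `COc1cccc(CNCCCNc2ccnc3cc(-c4ccc(C(F)(F)F)cc4)ccc23)c1O` gives 9.47. Compound 2 thus stands level with compounds 1 and 3 at the digits shown. Compound 4 `COc1ccc(F)cc1CNCCCNc1ccnc2cc(CCc3ccccc3)ccc12` has not yet been measured; it differs from compound 2 by phenethyl in place of cyclohexyl on an aromatic carbon. Within the data shown here, the one measured step that bears on this change, no change at the digits printed from compound 1 to compound 2 (within the scatter), also swapped the group on that same aromatic carbon and stayed within the scatter, so no step beyond the scatter is expected here either. Compound 4 is therefore estimated to give 9.47, within 9.2 to 9.75, an expected step of no change at the digits printed from compound 2 to compound 4 (within the scatter).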

Compound 4, acid dissociation constant: 9.47
Compound 4: the middle estimate sits on the measured number at the digits printed; the measured number falls inside the stated range.
By their numbers in this assay, from the lowest: compounds 1, 2, 3 and 4 (each within the scatter of the next).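

In this assay, phenethyl in place of cyclohexyl gives no change at the digits printed from compound 2 to compound 4 (within the scatter), so a six-membered aromatic ring and a non-aromatic one, both carbon only, are now matched on this aromatic carbon in a single step. Benzyl in place of 3,5-dimethylphenyl on the saturated chain carbon gives no change at the digits printed from compound 1 to compound 4 (within the scatter), so changing the outer part of this group also leaves the read-out within the scatter. Nothing available explains this lack of change. Still open, going by these compounds, is whether an amine or a carboxylic acid on this aromatic carbon would stay within the scatter in this assay.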